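The source may hold more compounds than are shown below. What is called first, only, known or untested is meant among the compounds shown, and "the series" means these compounds.

Among the compounds with values here, compound 3 `COc1ccc(-c2cc(C(=O)Nc3ccc(Oc4ccnc5[nH]ccc45)c(F)c3)ncn2)cc1` gives 10400 nM in a functional assay on MCF7 cells (Homo sapiens) for cytotoxicity, read by MTT assay, with a stated time of 72 h (on this read-out higher numbers stand for weaker inhibition and lower numbers for stronger inhibition), the highest of the three numbers measured so far; compound 1 `COc1ccc(-c2cc(C(=O)Nc3ccc(Oc4ccnc5[nH]ccc45)cc3)ncn2)cc1` gives 4450 nM and compound 2 `O=C(Nc1ccc(Oc2ccnc3[nH]ccc23)cc1)c1cc(-c2ccc(Cl)cc2)ncn1` gives 7770 nM. The measured steps are a 2.3-fold higher number from compound 1 to compound 3 (0.37 log units; beyond the scatter) and a 1.7-fold higher number from compound 1 to compound 2 (0.24 log units; within the scatter). Compound 4 `O=C(Nc1ccc(Oc2ccnc3[nH]ccc23)c(F)c1)c1cc(-c2ccc(C(F)(F)F)cc2)ncn1` differs from compound 3 by trifluoromethyl in place of methoxy on an aromatic carbon. Of the measured steps, only a 1.7-fold higher number from compound 1 to compound 2 (0.24 log units; within the scatter) bears on this change: it replaced the same methoxy at the same aromatic carbon and stayed within the scatter. Compound 4 is therefore expected to show at most a small move toward a higher number in this assay, with a 1.3-fold higher number from compound 3 to compound 4 (0.13 log units; within the scatter). The estimate for compound 4 is 14000 nM, with a range from 6000 nM to 32000 nM.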

Compound 4, half-maximal inhibitory concentration: 2840 nM
For compound 4 the middle estimate is 4.9-fold (0.69 log units) above the measured one; measured number outside the range, below it.
By their numbers in this assay, from the lowest: compounds 4, 1, 2 and 3 (each within the scatter of the next, the first and the last beyond it).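

In this assay, the change from 4-methoxyphenyl to 4-(trifluoromethyl)phenyl gives a 3.7-fold lower number from compound 3 to compound 4 (0.56 log units; beyond the scatter), so replacing methoxy at this aromatic carbon can shift the number beyond the scatter and toward stronger inhibition. The chloro replacement, on the core without the fluoro, did not show this: its step, a 1.7-fold higher number from compound 1 to compound 2 (0.24 log units; within the scatter), stayed within the scatter. Nothing available here accounts for the difference between the two replacements. On these data alone, whether trifluoromethyl gives a similar step on the core of compound 1 remains open. So does how a nitrile or an amine at this carbon would read.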